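Changing the amide ring once more on a shared core

The source may report more compounds than this note shows. Statements on the series, on what has been measured and on what is new or still open speak of the compounds shown alone.

Three compounds that share one core and differ only in the amine on the carbonyl carbon have been measured in a functional assay on KARPAS-299 cells (Homo sapiens) for antiproliferative activity, read by MTT assay, with a stated time of 4 h; on this read-out higher numbers stand for weaker inhibition and lower numbers for stronger inhibition. Compound 1 `CCN1CCN(C(=O)c2cccn2-c2ccc(Nc3ncc(Cl)c(Nc4ccccc4NS(C)(=O)=O)n3)c(OC)c2)CC1` gives 1410 nM in this assay. Compound 2 `COc1cc(-n2cccc2C(=O)N2CCCC2)ccc1Nc1ncc(Cl)c(Nc2ccccc2NS(C)(=O)=O)n1` gives 870 nM. Compound 3 `COc1cc(-n2cccc2C(=O)N2CCC(C)CC2)ccc1Nc1ncc(Cl)c(Nc2ccccc2NS(C)(=O)=O)n1` gives 1370 nM. On these three numbers compound 3 stands second highest; its nearest neighbour is compound 1, with a 1.0-fold lower number from compound 1 to compound 3 (0.01 log units; within the scatter), and the further one is compound 2, with a 1.6-fold higher number from compound 2 to compound 3 (0.20 log units; within the scatter). The remaining pair shows a 1.6-fold lower number from compound 1 to compound 2 (0.21 log units; within the scatter), so none of the three amine swaps at this position moved the read-out beyond the scatter.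

Compound 4 `COc1cc(-n2cccc2C(=O)N2CC(O)C2)ccc1Nc1ncc(Cl)c(Nc2ccccc2NS(C)(=O)=O)n1` differs from compound 3 in one place: 3-hydroxyazetidin-1-yl in place of 4-methylpiperidin-1-yl on a carbonyl carbon. The earlier steps shown here bear directly on this, since all three exchanged the amine on the same carbonyl carbon, and each stayed within the scatter. None of them, however, brought in a hydrogen-bond donor, so the measured steps say nothing about that part of the change. The expected outcome is therefore a step of a 1.1-fold lower number from compound 3 to compound 4 (0.06 log units; within the scatter) in this assay, that is, nothing beyond the scatter in either direction. Compound 4 is estimated at 1200 nM, with a range from 400 nM to 3600 nM.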

Compound 4, half-maximal inhibitory concentration: 81 nM
Beside the measured number, compound 4's estimate is 15-fold (1.17 log units) above it, outside the stated range (below it).
By their numbers in this assay, from the lowest: compound 4; then compounds 2, 3 and 1 (each within the scatter of the next).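

The amine on this carbonyl carbon turns out not to be a silent position in this assay: the new member gives a 17-fold lower number from compound 3 to compound 4 (1.23 log units; beyond the scatter) and an 11-fold lower number from compound 2 to compound 4 (1.03 log units; beyond the scatter) and also a 17-fold lower number from compound 1 to compound 4 (1.24 log units; beyond the scatter), whereas the three earlier amines stayed within the scatter of one another. For the compounds shown here, compound 4 is thus the strongest of the four on this read-out, and its 3-hydroxyazetidin-1-yl is the only amine here that carries a hydrogen-bond donor and the only one with a four-membered ring, so the position responds to something the piperazine, pyrrolidine and piperidine rings did not offer. No measurement in hand accounts for the size of this step.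

On these data alone, the step from compound 3 to compound 4 alters ring size and adds the hydroxyl together, so it remains open which of the two carries it, a question that a plain azetidin-1-yl, a 3-methoxyazetidin-1-yl or a 4-hydroxypiperidin-1-yl would help to settle. Also open, as far as these compounds go, is whether another group on the same ring, such as a 3-aminoazetidin-1-yl or a 3-carboxyazetidin-1-yl, would hold the number at the level of compound 4.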